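The source may hold more compounds than are shown below. What is called first, only, known or untested is meant among the compounds shown, and "the series" means these compounds.

Compound 1, `CCc1cccc(NC(=O)c2cccc(/C=C3\CC(=O)N(c4ccccc4)C3=O)c2)c1`, in an ADME assay on HCT-116 cells (Homo sapiens) for cytotoxicity, read by MTT assay, with a stated time of 72 h; a higher number here means a weaker inhibitor, a lower number a stronger inhibitor: 81200 nM
Compound 2, `O=C(c1cccc(/C=C2\CC(=O)N(c3ccccc3)C2=O)c1)N1CCCC1`: > 100000 nM, which is a limit of this assay, not a number

Compound 1 gives 81200 nM in this assay. Compound 2 reaches only the limit > 100000 nM. Where compound 2 stands is therefore known only as a bound; the step of an at least 1.2-fold higher number from compound 1 to compound 2 (0.09 log units; that floor lies within the scatter) rests on the limit of > 100000 nM in this assay, at which 1 of the 2 values shown sits, and cannot be sized beyond its floor.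

Compound 3, `O=C(Nc1ccc(Cl)cc1)c1cccc(/C=C2\CC(=O)N(c3ccccc3)C2=O)c1`, differs from compound 2 in one place: (4-chlorophenyl)amino in place of pyrrolidin-1-yl on a carbonyl carbon. For the measured compounds named here, the only measured step that bears on this change is an at least 1.2-fold higher number from compound 1 to compound 2 (0.09 log units; that floor lies within the scatter), which runs the other way, from an arylamino group to pyrrolidin-1-yl, and moved the number upward by at least its floor. Reversing that direction, from pyrrolidin-1-yl back to an arylamino group, is expected to bring compound 3 back toward the level of compound 1, with an at least 1.2-fold lower number from compound 2 to compound 3 (0.09 log units; that floor lies within the scatter) expected as a downward step in this assay. The estimate for compound 3 in this assay is 80000 nM, with a range of 30000 nM to 200000 nM.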

Compound 3, half-maximal inhibitory concentration: > 100000 nM
Compound 3: no number, only a limit (the forecaster's own chance of this, stated with the estimate: 40%); middle value at least 1.2-fold (0.09 log units) away from the limit.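

In this assay, 4-chlorophenyl in place of 3-ethylphenyl on the amide-type nitrogen gives an at least 1.2-fold higher number from compound 1 to compound 3 (0.09 log units; that floor lies within the scatter), so having an arylamino group on the carbonyl carbon does not alone bring a compound back to a measured number. Compound 1, with its 3-ethylphenyl group, remains the only one of the three with a number in this assay, and the floor of its step to compound 3 does not show that the two truly differ. The step from compound 2 to compound 3 cannot be read, and the pyrrolidin-1-yl and (4-chlorophenyl)amino groups cannot be ranked on this position, where the series now consists mostly of bounds: the limit of > 100000 nM in this assay, at which 2 of the 3 values shown sit.

On these data alone, how far compound 2 and compound 3 lie beyond the limit of the assay remains open, and so does the true size of the change from 3-ethylphenyl to 4-chlorophenyl. Also open, as far as these compounds go, is whether a dimethylamino group or a carboxylic acid in place of the chlorine of compound 3 would give a number rather than a limit.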